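The compounds below may be only part of what the source reports. "The series", "measured", "known", "first", "only" and "open" are said of these compounds alone.

In a functional assay on HEK293 cells for agonist activity at Neuronal acetylcholine receptor; alpha3/beta4 (Homo sapiens), read by FLIPR (on this read-out lower numbers stand for an effect already at smaller amounts and higher numbers for an effect only at larger amounts of compound), compound 2 `c1ncc(N2CC[C@H]3CN[C@H]3C2)cn1` gives 108 nM, the lowest of the two numbers in hand; compound 1 `COc1cncc(N2C[C@@H]3CCNC[C@@H]32)c1` gives 63500 nM, far beyond the scatter from compound 2. Compound 3 `c1ncc(N2CC[C@@H]3CN[C@@H]3C2)cn1` is still to be measured. From compound 2 to compound 3 the change is the two compounds have the same atoms and bonds and differ only in configuration as drawn: 2 of 2 stereo elements differ (all stereocentres are inverted: mirror images); a stereocentre at a saturated ring carbon is drawn S in compound 2 and R in compound 3; a stereocentre at a saturated ring carbon is drawn R in compound 2 and S in compound 3. Among the measured compounds shown here, no step between two measured compounds is available for this kind of change, and nothing here shows which mirror image carries the activity. Mirror images often differ well beyond the scatter, so the expected step from compound 2 to compound 3 is a 5.6-fold higher number from compound 2 to compound 3 (0.74 log units; beyond the scatter), upward, with wide uncertainty. Compound 3 is estimated at 600 nM, within 100 nM to 10000 nM.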

Compound 3, half-maximal effective concentration: 1020 nM
The estimate for compound 3 lay 1.7-fold (0.23 log units) below the measured number; the range from low to high includes it.
By their numbers in this assay, from the lowest: compound 2; then compound 3; then compound 1.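

In this assay, inverting both stereocentres gives a 9.4-fold higher number from compound 2 to compound 3 (0.98 log units; beyond the scatter), the first direct measure of what configuration alone does in this series. The pair isolates that change, so the step can be assigned to configuration and to nothing else: the fact that compounds 2 and 3 differ only in the configuration as drawn

Still open, from the compounds shown here alone, is whether the same mirror image keeps the lower number once a methoxy group, a nitrile or an amine sits on the shared core. Going by these compounds, the effect of inverting only one of the two stereocentres also remains unknown.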